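A few compounds are considered here, and "the series" means these few. Any claim that something is new, unique, unknown or untested is made for them only; others in the source may bear on it.

Working notes on the series, measured in an assay on isolated protein for inhibition of Ephrin type-A receptor 2 (Homo sapiens), read by thermal shift assay, tested at 10 uM; a higher number here means that the compound stabilises the target more against heat, a lower number that the compound stabilises the target less:

- compound 1 `CC(C)(C)c1cc(NC(=O)Nc2ccccc2)n(-c2ccccc2)n1` gives 1.6 degrees C
- compound 2 `Cc1ccc(NC(=O)Nc2cc(C(C)(C)C)nn2-c2ccccc2)cc1` gives 1.7 degrees C
- compound 3 `CC(C)(C)c1cc(NC(=O)Nc2cc(F)cc(F)c2)n(-c2ccccc2)n1` gives 2.7 degrees C

Compound 1 and compound 2 differ in one place: methyl in place of hydrogen on an aromatic carbon. The step this made is a number 0.10 degrees C higher from compound 1 to compound 2 (within the scatter), so the two values cannot be told apart within the usual scatter of this assay. Compound 3 differs from compound 1 as follows: 3,5-difluorophenyl in place of phenyl on an amide-type nitrogen; this is how the core of compound 3 differs from the core of compound 1. Among the compounds with values here, the step of a number 1.1 degrees C higher from compound 1 to compound 3 (beyond the scatter) is the one step in the set that is beyond the scatter, and compound 3 stands highest of the three, although against compound 2 the step of a number 1.0 degrees C higher from compound 2 to compound 3 (within the scatter) is within the scatter.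

Compound 4 `Cc1ccc(-n2nc(C(C)(C)C)cc2NC(=O)Nc2cc(F)cc(F)c2)cc1` has not yet been measured. It differs from compound 3 in one place: methyl in place of hydrogen on an aromatic carbon. The place is described in the same words as for the change from compound 1 to compound 2, so this is the same change made on the core of compound 3. Within the data shown here, the only precedent for it is the step of a number 0.10 degrees C higher from compound 1 to compound 2 (within the scatter), which is within the scatter. On that basis the step from compound 3 to compound 4 is expected to be about a number 0.10 degrees C higher from compound 3 to compound 4 (within the scatter), a change too small to separate from noise. Compound 4 is therefore estimated at 2.8 degrees C, with a range of 1.8 degrees C to 3.8 degrees C, resting on the value of compound 3, 2.7 degrees C, and on the precedent step.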

Compound 4, shift of the target's melting temperature: 1.9 degrees C
Compound 4: middle estimate off by 0.90 degrees C, on the high side; measured number inside the range.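

Methyl in place of hydrogen, read here as phenyl to 4-methylphenyl, gives in this assay a step of a number 0.80 degrees C lower from compound 3 to compound 4 (within the scatter). Set beside the earlier step, the two do not differ: the same change on two cores in this assay, a number 0.10 degrees C higher (within the scatter) from compound 1 to compound 2 and a number 0.80 degrees C lower (within the scatter) from compound 3 to compound 4, 0.90 degrees C apart, within the scatter of two such steps. Within the data shown here, this shows that neither core gives a step that can be told from noise and that the two cores cannot be separated on this change, but it does not establish that the change is neutral or that it carries reliably, since it rests on only two steps, and the structures show that the methyl of compound 4 stands on a different phenyl ring from the methyl of compound 2, despite the shared description.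

The compounds shown carry only hydrogen, methyl or fluorine on their phenyl rings, so it remains open whether an amine, a carboxylic acid or a longer chain in the place of the methyl would give a step beyond the scatter. Also open, on these data alone, is whether the methyl on the other phenyl ring gives a comparable step on the 3,5-difluorophenyl side of the series, and whether anything other than the tert-butyl group on the shared core would alter these readings.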